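Thiosemicarbazone pair: amino for dimethylamino, second core

The source may report more compounds than this note shows. Statements on the series, on what has been measured and on what is new or still open speak of the compounds shown alone.

Compound 1 `CN(C)C(=S)N/N=C/c1ccc2cccnc2n1` gives 970 nM in a functional assay on HeLa cells (Homo sapiens) for antiproliferative activity, read by sulforhodamine B assay, with a stated time of 72 h; on this read-out lower numbers stand for stronger inhibition and higher numbers for weaker inhibition. Compound 2 `NC(=S)N/N=C/c1ccc2cccnc2n1` gives only a limit in this assay, > 100000 nM, and no number. The change amino in place of dimethylamino on a thiocarbonyl carbon therefore made an at least 100-fold higher number from compound 1 to compound 2 (2.01 log units; beyond the scatter), a limit being involved (the limit of > 100000 nM in this assay, at which 1 of the 3 values shown sits). Compound 3 `CN(C)C(=S)N/N=C/c1cnc2ccccc2n1` gives 750 nM in this assay, which sits within the usual scatter of the value of compound 1; the difference between the two cores is not broken down here.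

Compound 4 `NC(=S)N/N=C/c1cnc2ccccc2n1` is not yet measured. It differs from compound 3 by amino in place of dimethylamino on a thiocarbonyl carbon, the same change as from compound 1 to compound 2, at the same place. With the cores of compound 1 and compound 3 giving such close numbers, the step is expected to carry over. The change is expected to make a step of about a 130-fold higher number from compound 3 to compound 4 (2.12 log units; beyond the scatter), beside the measured at least 100-fold higher number from compound 1 to compound 2 (2.01 log units; beyond the scatter). Compound 4 is accordingly estimated at 100000 nM in this assay, most likely again reported only as a limit, with a range from 20000 nM to 300000 nM.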

Compound 4, half-maximal inhibitory concentration: > 100000 nM
Compound 4: no number, only a limit; the forecaster's own chance of this, stated with the estimate: 70%; the middle value lies on the limit itself.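

On the second core, amino in place of dimethylamino on a thiocarbonyl carbon again gives a large step in this assay, an at least 130-fold higher number from compound 3 to compound 4 (2.12 log units; beyond the scatter). Compound 4 gives only a limit, > 100000 nM, so the direction of the change carries from one core to the other, while its size remains a lower bound on both: the same change on two cores in this assay, an at least 100-fold higher number (2.01 log units; beyond the scatter) from compound 1 to compound 2 and an at least 130-fold higher number (2.12 log units; beyond the scatter) from compound 3 to compound 4; the limit leaves it open whether they differ The two cores shown agree in that each dimethylamino compound gives a number and each amino compound gives only a limit, but this does not show the true size of either step or extend the carry-over past these two cores: the limit of > 100000 nM in this assay, at which 2 of the 4 values shown sit.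

The compounds shown leave open whether a single methyl group on this nitrogen, as in a methylamino group, would be enough to keep a measurable value. From the compounds shown here alone, how a larger amine such as diethylamino would read on either core also remains open.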